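From phenyl to pyridin-2-yl at the assay limit

This account rests on a few compounds, and the source may have more. Where it says the series, first, only, none or still open, it means among the compounds named here.

Measured so far in an ADME assay on P388D1 cells (Mus musculus) for cytotoxicity, read by fluorescence and resazurin assay, with a stated time of 72 h; a higher number here means a weaker inhibitor, a lower number a stronger inhibitor:
compound 1 (`O=C(c1cnc(NC(=O)C2CCCCC2)s1)c1cccc2ccccc12`) gives > 40000 nM as a limit
compound 2 (`O=C(CCC1CCCCC1)Nc1ncc(Cc2ccccc2)s1`) gives > 40000 nM as a limit
compound 3 (`O=C(Nc1ncc(Cc2cccc3ccccc23)s1)C1CCCCC1`) gives > 40000 nM as a limit

For the measured compounds named here, none of these three compounds has a number of its own, so no step between them can be read. Compound 2 reads > 40000 nM in this assay and this is a limit, not a number. It shares that position with the other two, as the record shows: the limit of > 40000 nM in this assay, at which 3 of the 3 values shown sit, is all the set offers.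

Compound 4 (`O=C(CCC1CCCCC1)Nc1ncc(Cc2ccccn2)s1`) has not yet been measured. The change from compound 2 is pyridin-2-yl in place of phenyl on a saturated chain carbon bound to an aromatic carbon and in words it is pyridin-2-yl in place of phenyl on a saturated chain carbon bound to an aromatic carbon.

Going by the values given here, no measured pair in this small set shows what such an exchange does. The starting point for the expectation is therefore only compound 2 at > 40000 nM as a limit. No step beyond the usual scatter is expected in this assay in either direction, and a further limit is the likeliest report. The estimated change is a number no higher from compound 2 to compound 4 (the limit leaves the size open) and it is expected to be negligible. For compound 4 the estimate is 40000 nM with an expected range from 18000 nM to 80000 nM as its span.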

Compound 4, half-maximal inhibitory concentration: > 40000 nM
Compound 4 was reported as a limit; the forecaster's own chance of this, stated with the estimate: 75%; the middle value lies on the limit itself.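

In this assay compound 4 gives > 40000 nM, which is a limit. Compound 2 also stands at a limit, so no step can be read between compound 2 and compound 4, and the set stays where it was: the limit of > 40000 nM in this assay, at which 4 of the 4 values shown sit.

The compounds shown leave open what pyridin-2-yl in place of phenyl does to a value with a number of its own in this assay.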